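Swapping the sulfur-containing ring for a small aromatic ring

This account rests on a few compounds, and the source may have more. Where it says the series, first, only, none or still open, it means among the compounds named here.

Three compounds share one core and differ only in the group attached to a saturated chain carbon bound to an aromatic carbon and a saturated chain carbon. Compound 1 `CC(C)C(c1ccc(-c2ccc3cccc(F)c3c2)[nH]c1=O)N1CCCCS1(=O)=O` carries a six-membered ring containing sulfur at that position; compound 2 `CC(C)C(c1ncco1)c1ccc(-c2ccc3cccc(F)c3c2)[nH]c1=O` carries 1,3-oxazol-2-yl, and compound 3 `CC(C)C(c1ccc(-c2ccc3cccc(F)c3c2)[nH]c1=O)N1CCCCC1=O` carries 2-oxopiperidin-1-yl. In an ADME assay on microsomes from liver (Mus musculus) for metabolic stability (a lower number here means that the compound disappears faster, a higher number that the compound lasts longer), compound 1 gives 0.0733 h, compound 2 gives 0.08 h and compound 3 gives 0.0967 h. Compound 1 has the smallest of these three numbers, but the step of a 1.1-fold higher number from compound 1 to compound 2 (0.04 log units; within the scatter) and the step of a 1.3-fold higher number from compound 1 to compound 3 (0.12 log units; within the scatter) both stay within the scatter, so the three compounds cannot really be told apart in this assay.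

Compound 4 `CC(C)C(Cc1noc(=O)[nH]1)c1ccc(-c2ccc3cccc(F)c3c2)[nH]c1=O` continues the same kind of exchange: a group of 7 heavy atoms (3 carbon, 2 nitrogen, 2 oxygen; one five-membered aromatic ring with 3 hetero atoms) in place of a group of 8 heavy atoms (4 carbon, 1 nitrogen, 2 oxygen, 1 sulfur; one six-membered non-aromatic ring with 2 hetero atoms), on a saturated chain carbon bound to an aromatic carbon and a saturated chain carbon. The step from compound 1 to compound 2, which also brought in a five-membered aromatic ring in place of the sulfur-containing ring, changed the number only within the scatter, and the step to compound 3 did likewise. Among the compounds with values here, no measured step therefore points to a change beyond the scatter in this assay.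

Compound 4 is expected to give about 0.08 h, with a range from 0.04 h to 0.16 h. This estimate means a step of a 1.1-fold higher number from compound 1 to compound 4 (0.04 log units; within the scatter), expected to stay within the scatter.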

Compound 4, half-life: 2.78 h
Compound 4: the middle estimate sits 35-fold (1.54 log units) below what was measured; the measured number lies above the stated range.
By their numbers in this assay, from the lowest: compounds 1, 2 and 3 (each within the scatter of the next); then compound 4.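

In this assay, the first three compounds made this position look indifferent, but the group entering in compound 4 changes that: the saturated chain carbon bound to an aromatic carbon and a saturated chain carbon can carry a very large difference, with a 38-fold higher number from compound 1 to compound 4 (1.58 log units; beyond the scatter) against the sulfur-containing ring and a 29-fold higher number from compound 3 to compound 4 (1.46 log units; beyond the scatter) against 2-oxopiperidin-1-yl. A five-membered aromatic ring at this place is not enough on its own, as compound 2 with 1,3-oxazol-2-yl stays with compounds 1 and 3, and there is still a 35-fold higher number from compound 2 to compound 4 (1.54 log units; beyond the scatter) when one such ring replaces another. Nothing at hand tells what in the group of compound 4 accounts for this jump.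

The compounds shown leave open whether the jump belongs to the ring with 3 hetero atoms, to its hydrogen-bond donor or to some other part of the group. They also leave open whether a carboxylic acid or an amine at this same place would fall with compound 4 or with compounds 1, 2 and 3.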